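This account rests on a few compounds, and the source may have more. Where it says the series, first, only, none or still open, it means among the compounds named here.

In a functional assay on cells for antagonist activity at C-C chemokine receptor type 1 (Homo sapiens), read by FLIPR and calcium flux (a lower number here means a stronger inhibitor, a higher number a weaker inhibitor), compound 1 `Cc1c(C(=O)NCc2cccc(C(F)(F)F)c2)cnn1-c1ccc(Cl)cc1` gives 600 nM. Compound 2 `Cc1c(C(=O)NCc2cccc(C(F)(F)F)c2)cnn1-c1cccc(Cl)c1` reaches only a limit of the assay in this assay, > 3000 nM. Compound 3 `Cc1cccc(-n2ncc(C(=O)NCc3cccc(C(F)(F)F)c3)c2C)c1` likewise reaches only a limit, > 3000 nM, so where it stands is known only as no stronger than that limit. This is visible in the limit of > 3000 nM in this assay, at which 2 of the 3 values shown sit. The steps of an at least 5.0-fold higher number from compound 1 to compound 2 (0.69 log units; beyond the scatter) and an at least 5.0-fold higher number from compound 1 to compound 3 (0.69 log units; beyond the scatter) both show that 4-chlorophenyl on the aromatic nitrogen gives a stronger inhibitor than 3-chlorophenyl or 3-methylphenyl. The step that the two limits leave unreadable from compound 2 to compound 3 cannot be sized, as both ends are limits.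

Compound 4 `Cc1c(C(=O)NCc2cccc(C(F)(F)F)c2)cnn1-c1ccc([N+](=O)[O-])cc1` differs from compound 3 as follows: 4-nitrophenyl in place of 3-methylphenyl on an aromatic nitrogen. Compound 1 also carries a group on that nitrogen named 4-chlorophenyl, and in this assay compound 1 gives 600 nM, while a nitro group has not been measured anywhere here. The step of an at least 2.0-fold lower number from compound 3 to compound 4 (0.30 log units; that floor lies within the scatter) is expected to run towards a stronger inhibitor, though its size is uncertain. Compound 4 is therefore estimated at 1500 nM, with a range from 400 nM to 5000 nM.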

Compound 4, half-maximal inhibitory concentration: 960 nM
The estimate for compound 4 lay 1.6-fold (0.19 log units) above the measured number; the range from low to high includes it.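

Going by these compounds alone, compound 4 shows that 4-chlorophenyl is not the only group on the aromatic nitrogen that gives a readable number in this assay, since 4-nitrophenyl gives one too, with an at least 3.1-fold lower number from compound 3 to compound 4 (0.49 log units; beyond the scatter) and an at least 3.1-fold lower number from compound 2 to compound 4 (0.49 log units; beyond the scatter). Swapping nitro for chloro on that same ring gives a 1.6-fold higher number from compound 1 to compound 4 (0.20 log units; within the scatter), so the two groups cannot be told apart here, and among these four compounds the two 4-substituted phenyl groups give readable numbers while the two 3-substituted ones do not. The first two steps are only floors, because compounds 2 and 3 each stand at a limit of the assay rather than at a number: the limit of > 3000 nM in this assay, at which 2 of the 4 values shown sit.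

Still open, on these data alone, is whether a smaller or very different group on the phenyl ring, such as the methyl of 4-methylphenyl, an amine or a carboxylic acid, would keep this level of inhibition. Also open, as far as these compounds go, is how 3-nitrophenyl or an unsubstituted phenyl would compare.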